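Extending the chain of compound 2 by one carbon

This account rests on a few compounds, and the source may have more. Where it says the series, first, only, none or still open, it means among the compounds named here.

Compound 2, `CC=C(c1cc(OC)cc(OC)c1)c1ccc(OC)c(OC)c1`, gives 480 nM in a functional assay on HCT-116 cells (Homo sapiens) for cytotoxicity, read by scintillation counting and thymidine incorporation, with a stated time of 72 h (on this read-out lower numbers stand for stronger inhibition and higher numbers for weaker inhibition), the highest of the three numbers recorded there. Among the compounds with values here, compound 1, `CCOc1cc(C(=CC#N)c2ccc(OC)c(-n3cccc3)c2)ccc1OC`, gives 49 nM, and compound 3, `CC=C(c1cc(OC)cc(OC)c1)c1ccc(OC)c(O)c1`, gives 30 nM; the single measured step, a 16-fold lower number from compound 2 to compound 3 (1.20 log units; beyond the scatter), came from a hydrogen in place of methyl on an oxygen on an aromatic ring. Compound 4, `CCC=C(c1cc(OC)cc(OC)c1)c1ccc(OC)c(OC)c1`, differs from compound 2 only at the chain: methyl in place of hydrogen on a saturated chain carbon bound to a double-bonded chain carbon. Within the data shown here, no measured step touches this chain position, so there is nothing in the data to suggest a change beyond the scatter in either direction. The number for compound 4 is therefore expected to sit close to that of compound 2, at 500 nM with a range of 200 nM to 1300 nM, which is estimated to mean a 1.0-fold higher number from compound 2 to compound 4 (0.02 log units; within the scatter).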

Compound 4, half-maximal inhibitory concentration: > 10000 nM
Compound 4: only a limit was reported (the forecaster's own chance of this, stated with the estimate: 2%); at least 20-fold (1.30 log units) between middle value and limit.
By their numbers in this assay, from the lowest: compounds 3 and 1 (each within the scatter of the next); then compound 2. At a limit, above all of these: compound 4.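

In this assay, within the data shown here, the earlier compounds showed a large step only at an oxygen on an aromatic ring, while the chain was untested; methyl to ethyl on the saturated chain carbon bound to a double-bonded chain carbon now gives an at least 20-fold higher number from compound 2 to compound 4 (1.31 log units; beyond the scatter). This position is therefore far from indifferent to one added carbon. For compound 4 only a limit stands: the limit of > 10000 nM in this assay, at which 1 of the 4 values shown sits.

From the compounds shown here alone, whether a longer chain or an amine at this place would give a number at all stays open. So does whether hydrogen in place of methyl on an oxygen on an aromatic ring would lower the number for compound 4 as it does for compound 2.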